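From Propyl to Isopropyl on Compound 2

A few compounds are considered here, and "the series" means these few. Any claim that something is new, unique, unknown or untested is made for them only; others in the source may bear on it.

Compound 1 `CC(C)(C)N(NC(=O)c1ccc(I)cc1)C(=O)c1ccccc1Cl` and compound 2 `CCCc1ccc(C(=O)NN(C(=O)c2ccccc2Cl)C(C)(C)C)cc1` share one core and differ only in one group on an aromatic carbon. In an assay on cells for agonist activity at ecdysone receptor (Bombyx mori), read by a luciferase reporter, with a stated time of 24 h (on this read-out higher numbers stand for an effect only at larger amounts of compound and lower numbers for an effect already at smaller amounts), compound 1 gives 7.59 nM, and compound 2 gives 9.12 nM; the step of a 1.2-fold higher number from compound 1 to compound 2 (0.08 log units; within the scatter) lies within the scatter. Among the two numbers so far, compound 2 stands at one end, with compound 1 within the scatter of it, so the two cannot be told apart. Compound 3 `CC(C)c1ccc(C(=O)NN(C(=O)c2ccccc2Cl)C(C)(C)C)cc1` differs from compound 2 by isopropyl in place of propyl on an aromatic carbon. Among the measured compounds shown here, only one measured step bears on this change, a 1.2-fold higher number from compound 1 to compound 2 (0.08 log units; within the scatter), and it stayed within the scatter; it concerns a different pair of groups at that carbon, so it speaks only faintly. In this assay compound 3 is expected to show a step of a 1.0-fold lower number from compound 2 to compound 3 (0.01 log units; within the scatter) that stays within the scatter. Compound 3 is estimated at 9 nM, with a range from 4 nM to 20 nM.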

Compound 3, half-maximal effective concentration: 24.6 nM
For compound 3 the middle estimate is 2.7-fold (0.44 log units) below the measured one, outside the stated range (above it).
By their numbers in this assay, from the lowest: compounds 1 and 2 (each within the scatter of the next); then compound 3.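

In this assay, the aromatic carbon para to a large group now shows a response that the earlier pair did not reveal. Propyl and isopropyl hold the same atoms, joined differently, yet this rearrangement gives a 2.7-fold higher number from compound 2 to compound 3 (0.43 log units; beyond the scatter), while isopropyl in place of iodo gives a 3.2-fold higher number from compound 1 to compound 3 (0.51 log units; beyond the scatter), so among these three compounds isopropyl alone stands apart. Nothing at hand explains why the two chains differ in this way.

The three compounds leave open whether the higher number belongs to isopropyl alone or extends to other branched groups at this carbon, such as tert-butyl or cyclopropyl. They also leave open how a longer straight chain such as butyl, or an amine, would read at the same carbon.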